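From a hydroxy-bearing ester to an oxolane ester

The source may report more compounds than this note shows. Statements on the series, on what has been measured and on what is new or still open speak of the compounds shown alone.

Measured in a functional assay on HeLa cells (Homo sapiens) for cytotoxicity, read by MTT assay; a higher number here means a weaker inhibitor, a lower number a stronger inhibitor:
- compound 1 `CC(C)=CC[C@@H](OC(=O)CCO)C1=CC(=O)c2c(O)ccc(O)c2C1=O`: 67600 nM
- compound 2 `CC(C)=CC[C@@H](OC(=O)C1CCOC1)C1=CC(=O)c2c(O)ccc(O)c2C1=O`: 73500 nM
- compound 3 `CC[C@@](C)(O)CC(=O)O[C@H](CC=C(C)C)C1=CC(=O)c2c(O)ccc(O)c2C1=O`: 17900 nM

Compound 3 has the lowest number of the three, and its steps to both others lie beyond the scatter. The next compound, compound 4 `CC(C)=CC[C@@H](OC(=O)C1CCCO1)C1=CC(=O)c2c(O)ccc(O)c2C1=O`, differs from it in one place: oxolan-2-yl in place of 2-hydroxy-2-methylbutyl on a carbonyl carbon. Oxolan-2-yl stands in place of 2-hydroxy-2-methylbutyl on a carbonyl carbon. The nearest measured comparison is compound 2, which carries oxolan-3-yl on that carbonyl carbon, and a 4.1-fold lower number from compound 2 to compound 3 (0.61 log units; beyond the scatter) is a modest step that would here run in reverse. The step of a 3.8-fold lower number from compound 1 to compound 3 (0.58 log units; beyond the scatter) is also modest, while a 1.1-fold higher number from compound 1 to compound 2 (0.04 log units; within the scatter) stays within the scatter. Within the data shown here, no measurement yet shows what oxolan-2-yl does compared with oxolan-3-yl. A modest move toward a higher number is therefore expected, and the expected change is a 3.2-fold higher number from compound 3 to compound 4 (0.51 log units; beyond the scatter). In this assay the estimated value for compound 4 is 58000 nM, with an expected range of 27000 nM to 110000 nM.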

Compound 4, half-maximal inhibitory concentration: 17000 nM
Compound 4: middle estimate off by 3.4-fold (0.53 log units), on the high side; measured number below the stated range.
By their numbers in this assay, from the lowest: compounds 4 and 3 (each within the scatter of the next); then compounds 1 and 2 (each within the scatter of the next).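

In this assay the point at which the oxolane ring joins the carbonyl carbon proves to matter, since oxolan-2-yl in place of oxolan-3-yl gives a clear change (a 4.3-fold lower number from compound 2 to compound 4 (0.64 log units; beyond the scatter)). The ring with 0 hydrogen-bond donors also matches the open 2-hydroxy-2-methylbutyl chain (a 1.1-fold lower number from compound 3 to compound 4 (0.02 log units; within the scatter)), and it separates from the 2-hydroxyethyl of compound 1 (a 4.0-fold lower number from compound 1 to compound 4 (0.60 log units; beyond the scatter)), so among these compounds a hydroxy group on this ester is not needed to reach the lower numbers. Nothing available accounts for these differences.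

The compounds shown leave open how cyclopentyl, which lacks the ring oxygen, or a six-membered oxan-2-yl ring would read on this carbonyl carbon. They also leave open what an amine or a carboxylic acid on the oxolan-2-yl ring would do.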